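A Hydroxy Analogue of the Most Active Compound

This account rests on a few compounds, and the source may have more. Where it says the series, first, only, none or still open, it means among the compounds named here.

Compound 1 `COc1cc(C)cc(-c2nn(CC#N)cc2-c2ccc(-c3cccc(C(C)=O)c3)nc2)c1`: 89%
Compound 2 `Cc1cc(O)cc(-c2nn(CC#N)cc2-c2ccnc(-c3ccc(Oc4ccccc4)cc3)c2)c1`: 77%
Compound 3 `COc1cc(C)cc(-c2nn(CC#N)cc2-c2ccnc(-c3ccc(N(C)C)cc3)c2)c1`: 43%

All three were tested in a functional assay on EKVX cells (Homo sapiens) for cytotoxicity, read by sulforhodamine B assay, with a stated time of 48 h, tested at 100 nM; a higher number here means a weaker effect of the compound at the concentration tested, a lower number a stronger effect. Compound 3 gives the lowest number of the three and therefore the strongest effect; compound 2 lies above it by a gap beyond the scatter, and compound 1 lies further above still. Compound 4 `Cc1cc(O)cc(-c2nn(CC#N)cc2-c2ccnc(-c3ccc(N(C)C)cc3)c2)c1` has not yet been measured. It differs from compound 3 in one place: hydrogen in place of methyl on an oxygen on an aromatic ring. Among the measured compounds shown here, compound 2 also carries a hydroxy and in this assay compound 2 gave 77%, but its other end of the molecule differs, so no direct step for this change is known. A moderate weakening is expected, a number 12 percentage points higher from compound 3 to compound 4 (beyond the scatter). Compound 4 is estimated at 55%, with a range from 35% to 80%.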

Compound 4, a percentage reported as activity, at one concentration (the size of the read-out at that concentration, not a potency): 81%
Estimate against measurement, compound 4: 26 percentage points below, and the stated range ends below it.
By their numbers in this assay, from the lowest: compound 3; then compounds 2, 4 and 1 (each within the scatter of the next, the first and the last beyond it).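

In this assay, the methyl on the oxygen proves to matter far more than compound 2 could suggest: methoxy to hydroxy on the aromatic ring removes much of the effect (a number 38 percentage points higher from compound 3 to compound 4 (beyond the scatter)). With the hydroxy in place, dimethylamino in place of phenoxy makes no difference that can be told from the scatter (a number 4 percentage points higher from compound 2 to compound 4 (within the scatter)). No data given here explain either step.

As far as these compounds go, it remains open whether an ethoxy or an amino group at this position would keep the effect of compound 3. From the compounds shown here alone, it is also open whether methoxy to hydroxy costs as much with phenoxy at the other end.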